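Nitrogen substituent variation on the shared core

This account rests on a few compounds, and the source may have more. Where it says the series, first, only, none or still open, it means among the compounds named here.

Measured compounds:
compound 1 `CC(C)=CCn1ccc2cc(/C(C)=C/C(=O)Nc3ccccc3OCCCC(=O)O)ccc21` — 120 nM
compound 2 `CCC(C)n1ccc2cc(/C(C)=C/C(=O)Nc3ccccc3OCCCC(=O)O)ccc21` — 67 nM
compound 3 `C/C(=C\C(=O)Nc1ccccc1OCCCC(=O)O)c1ccc2c(ccn2Cc2ccc(F)cc2)c1` — 97 nM

In an assay on Prostate gland for inhibition of steroid 5-alpha-reductase (Rattus norvegicus) (on this read-out lower numbers stand for stronger inhibition and higher numbers for weaker inhibition), compound 3 gives 97 nM and sits second highest of the three numbers; its nearest neighbour is compound 1 at 120 nM, its furthest compound 2 at 67 nM; both gaps lie within the scatter.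

The untested compound 4 `CCCCC(c1ccccc1)n1ccc2cc(/C(C)=C/C(=O)Nc3ccccc3OCCCC(=O)O)ccc21` carries the change 1-phenylpentyl in place of 4-fluorobenzyl on an aromatic nitrogen on the aromatic nitrogen of the shared core.

Among the compounds with values here, three measured steps bear on changes at this nitrogen: a 1.8-fold lower number from compound 1 to compound 2 (0.25 log units; within the scatter), a 1.2-fold lower number from compound 1 to compound 3 (0.09 log units; within the scatter) and a 1.4-fold higher number from compound 2 to compound 3 (0.16 log units; within the scatter). All three exchanges of the group on the aromatic nitrogen leave the number within the scatter, so no step beyond the scatter is expected for compound 4 in this assay either; 1-phenylpentyl is compared here without a direct precedent, which widens the range rather than the direction.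

Estimated outcome for compound 4 in this assay: 90 nM, range 40 nM to 220 nM, corresponding to an expected step of a 1.1-fold lower number from compound 3 to compound 4 (0.03 log units; within the scatter).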

Compound 4, half-maximal inhibitory concentration: 9.8 nM
Beside the measured number, compound 4's estimate is 9.2-fold (0.96 log units) above it; the measured number lies below the stated range.
By their numbers in this assay, from the lowest: compound 4; then compounds 2, 3 and 1 (each within the scatter of the next).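

In this assay, the group on the aromatic nitrogen turns out to matter: the earlier exchanges all stayed within the scatter, whereas 1-phenylpentyl stands clear of all three earlier groups, with steps beyond the scatter against 4-fluorobenzyl (a 9.9-fold lower number from compound 3 to compound 4 (1.00 log units; beyond the scatter)), sec-butyl (a 6.8-fold lower number from compound 2 to compound 4 (0.83 log units; beyond the scatter)) and 3-methylbut-2-en-1-yl (a 12-fold lower number from compound 1 to compound 4 (1.09 log units; beyond the scatter)). Against 4-fluorobenzyl, the one six-membered aromatic ring of carbon only is retained and neither group has hydrogen-bond donors or acceptors, so the counted differences are the loss of fluorine and 11 heavy atoms in place of 8. Nothing available here accounts for the size of this step.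

The compounds shown do not separate the contributions of the phenyl ring and the butyl portion of 1-phenylpentyl, which a comparison with 1-phenylethyl, 1-phenylpropyl or 1-cyclohexylpentyl would begin to address. Also open, on these data alone, are whether fluorine on the phenyl ring of 1-phenylpentyl changes the number, whether a longer chain such as 1-phenylheptyl goes further, and whether a terminal amine or carboxylic acid on the pentyl chain is accepted.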